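A few compounds are considered here, and "the series" means these few. Any claim that something is new, unique, unknown or untested is made for them only; others in the source may bear on it.

In a functional assay on CWR22R cells (Homo sapiens) for antiproliferative activity, read by MTT assay, with a stated time of 3 days (on this read-out lower numbers stand for stronger inhibition and higher numbers for weaker inhibition), compound 2 `COc1cc(O)c2c(=O)cc(-c3ccc(NC(=O)NC4CC4)cc3)oc2c1OC(C)C` stands at 6700 nM as the higher of two numbers, while compound 1 `CCS(=O)(=O)Nc1ccc(-c2cc(=O)c3c(O)cc(OC)c(OC(C)C)c3o2)cc1` stands at 2900 nM on the same read-out. Compound 3 `COc1cc(O)c2c(=O)cc(-c3ccc(NC(=O)N4CCCNCC4)cc3)oc2c1OC(C)C` differs from compound 2 by 1,4-diazepan-1-yl in place of cyclopropylamino on a carbonyl carbon. Going by the values given here, the one measured step that bears on this, a 2.3-fold higher number from compound 1 to compound 2 (0.36 log units; beyond the scatter) for another change, is modest and gives no firm direction, so a step of no greater size is expected in this assay here. The expected move is a 1.7-fold lower number from compound 2 to compound 3 (0.22 log units; within the scatter) on this estimate. Compound 3 is estimated at 4000 nM with an expected range from 1300 nM to 12000 nM as its span.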

Compound 3, half-maximal inhibitory concentration: 6100 nM
Estimate against measurement, compound 3: 1.5-fold (0.18 log units) below; measured number inside the range.
By their numbers in this assay, from the lowest: compound 1; then compounds 3 and 2 (each within the scatter of the next).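

In this assay, 1,4-diazepan-1-yl in place of cyclopropylamino on the carbonyl carbon gives a 1.1-fold lower number from compound 2 to compound 3 (0.04 log units; within the scatter), so at this position the seven-membered ring with its second nitrogen is not told apart from the three-membered ring. Against ethylsulfonyl on the nitrogen, (1,4-diazepan-1-yl)carbonyl gives a 2.1-fold higher number from compound 1 to compound 3 (0.32 log units; beyond the scatter), a modest step that matches the direction already seen with cyclopropylcarbamoyl. No available evidence accounts for either step. The compounds shown leave open whether a morpholin-4-yl or dimethylamino group on the same carbonyl carbon would also stay within the scatter.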